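Swapping a Methyl for a Bromine on the Aryl Amide

This account rests on a few compounds, and the source may have more. Where it says the series, first, only, none or still open, it means among the compounds named here.

Among the measured compounds shown here, compound 2 `Cc1cccc(C(=O)Nc2c(C(O)(C(F)(F)F)C(F)(F)F)ccc3ccccc23)c1` has the lowest of the two numbers measured so far: in an assay on LtK cells with ATP-sensitive inward rectifier potassium channel 11 (Homo sapiens) as the target (on this read-out higher numbers stand for an effect only at larger amounts of compound and lower numbers for an effect already at smaller amounts), compound 2 gives 23 nM. For the measured compounds named here, its only measured neighbour is compound 1 `O=C(Nc1c(C(O)(C(F)(F)F)C(F)(F)F)ccc2ccccc12)c1cccc(Cl)c1`, which in this assay gives 98 nM; the step of a 4.3-fold lower number from compound 1 to compound 2 (0.63 log units; beyond the scatter) is the one comparison available. Compound 3 `O=C(Nc1c(C(O)(C(F)(F)F)C(F)(F)F)ccc2ccccc12)c1ccc(Br)cc1` differs from compound 2 by 4-bromophenyl in place of 3-methylphenyl on a carbonyl carbon. Going by the values given here, no measured step makes exactly this change; the step from compound 1 to compound 2 exchanged a halogen for a methyl, and returning to a halogen, now bromine, is the nearest guide, though the halogen also sits on a different carbon of the ring. Compound 3 is therefore expected to show a step of a 3.5-fold higher number from compound 2 to compound 3 (0.54 log units; beyond the scatter) in this assay, toward a higher number, with wide uncertainty. The estimate for compound 3 in this assay is 80 nM, within 25 nM to 250 nM.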

Compound 3, half-maximal effective concentration: 47 nM
Beside the measured number, compound 3's estimate is 1.7-fold (0.23 log units) above it; low and high end bracket the measured number.
By their numbers in this assay, from the lowest: compound 2; then compound 3; then compound 1.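

In this assay the group on the carbonyl carbon moves the number again, with a 2.0-fold higher number from compound 2 to compound 3 (0.31 log units; beyond the scatter), and with a 2.1-fold lower number from compound 1 to compound 3 (0.32 log units; beyond the scatter). A halogen on this ring therefore does not by itself give a number as high as that of compound 1: compound 3, with 4-bromophenyl, falls in the middle, while compound 2, with 3-methylphenyl, keeps the lowest number of the three. The step between the two halogen compounds changes both the halogen and the carbon that carries it, and nothing available gives a reason for this order.

Whether the identity of the halogen or the carbon it sits on accounts for that step stays open. Also open, as far as these compounds go, is how this ring would read with an amine or a carboxylic acid in place of the methyl or the halogen.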